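Series notes: allyl for phenyl on the aromatic nitrogen

The source may report more compounds than this note shows. Statements on the series, on what has been measured and on what is new or still open speak of the compounds shown alone.

Compound 3 `COc1cc(-c2nnc(SCC(=O)Nc3ccc(C(C)=O)cc3)n2-c2ccccc2)cc(OC)c1OC` has been run in a functional assay on the whole organism (strain albino) for inhibition, with Rattus norvegicus as the target, read by paw edema, with stated times of 30 min and 3 h, at a dose of 0.28 mmol/kg by the oral route (on this read-out lower numbers stand for less inhibition and higher numbers for more inhibition at the one dose given (going by the name of the read-out)), where compound 3 gives 55%. Among the three values shown, compound 3 stands second highest; compound 2 `CCn1c(SCC(=O)Nc2ccc(C(C)=O)cc2)nnc1-c1cc(OC)c(OC)c(OC)c1` gives 54% and compound 1 `C=CCn1c(SCC(=O)Nc2ccc(C(C)=O)cc2)nnc1-c1ccc(OC)c(OC)c1` gives 58%. All three values lie within the scatter of each other, so no ordering among them can be claimed.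

Compound 4 `C=CCn1c(SCC(=O)Nc2ccc(C(C)=O)cc2)nnc1-c1cc(OC)c(OC)c(OC)c1` has not yet been measured. It differs from compound 3 in one place: allyl in place of phenyl on an aromatic nitrogen.

Among the compounds with values here, one measured step bears on this change, since it also exchanges the group on the aromatic nitrogen: a number 1 percentage points higher from compound 2 to compound 3 (within the scatter). That step stayed within the scatter. Within the data shown here, compound 1 carries the allyl group that enters here, but it also carries a different aryl group on the other side of the shared core, and no single-point step connects it to compound 4; its value shows only that an allyl-bearing member of the series sits at a similar level to the rest.

The step from compound 3 to compound 4 in this assay is therefore expected to be a number 1 percentage points higher from compound 3 to compound 4 (within the scatter), within the scatter. Compound 4 is estimated at 56%, with a range from 48% to 64%.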

Compound 4, a percentage reported as inhibition, in the whole organism at one dose (the size of the read-out at that dose, not a potency): 55%
Estimate against measurement, compound 4: 1 percentage points above, and the stated range covers the measured number.
By their numbers in this assay, from the lowest: compounds 2, 3, 4 and 1 (each within the scatter of the next).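

On the aromatic nitrogen next to the ring atom that bears a 3,4,5-trimethoxyphenyl group, replacing phenyl with allyl in this assay gives no change at the digits printed from compound 3 to compound 4 (within the scatter), and the comparison with the ethyl member gives a number 1 percentage points higher from compound 2 to compound 4 (within the scatter), so ethyl, phenyl and allyl cannot be told apart at this position with the aryl group held fixed. Within the data shown here, compound 4 also supplies the first single-place comparison on the aryl side, where the step for methoxy in place of hydrogen on an aromatic carbon, read in the opposite direction, is a number 3 percentage points lower from compound 1 to compound 4 (within the scatter), so the dimethoxy and trimethoxy patterns cannot be told apart in the allyl pair either. No supporting data are available to explain this flat pattern.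

The compounds shown leave open whether a longer chain, an amine or a carboxylic acid on this nitrogen would move the paw edema read-out beyond the scatter. They also leave open whether compounds that cannot be separated at this one oral dose would still differ across a range of doses.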